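From a Thioether to an Aryl Ether, Before Measurement

The source may hold more compounds than are shown below. What is called first, only, known or untested is meant among the compounds shown, and "the series" means these compounds.

Compound 1 `CCOC(=O)[C@H](CCC(=O)O)NC(=O)c1ccc(Sc2nc3cc(N)cc(N)c3nc2-c2ccccc2)cc1`: in a functional assay on UACC-62 cells (Homo sapiens) for inhibition, read by sulforhodamine B assay, with a stated time of 48 h (on this read-out lower numbers stand for stronger inhibition of growth and higher numbers for weaker inhibition of growth), compound 1 gives 38900 nM.
Compound 2 `COc1ccc(Sc2nc3cc(N)cc(N)c3nc2-c2ccccc2)cc1`: in this assay compound 2 gives only a limit, < 100000 nM.

For compound 2 the only fixed point is the limit of < 100000 nM in this assay, at which 1 of the 2 values shown sits. Compound 3 `Nc1cc(N)c2nc(-c3ccccc3)c(Oc3ccc(F)cc3)nc2c1` has not yet been measured. It differs from compound 2 by 4-fluorophenoxy in place of (4-methoxyphenyl)sulfanyl on an aromatic carbon. Among the measured compounds shown here, no step between measured compounds has been worked out, and compound 2 rests on a limit alone, so the expected step that the limit leaves unreadable from compound 2 to compound 3 in this assay is modest and of uncertain direction. Compound 3 is expected to give 35000 nM, within 6000 nM to 100000 nM.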

Compound 3, concentration for total growth inhibition: 33100 nM
Compound 3: the middle estimate sits 1.1-fold (0.02 log units) above what was measured; the range from low to high includes it.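

No step can be read from compound 2 to compound 3, because compound 2 rests on a limit alone: the limit of < 100000 nM in this assay, at which 1 of the 3 values shown sits.
The compounds shown leave open whether 4-fluorophenoxy in place of (4-methoxyphenyl)sulfanyl strengthens, weakens or leaves unchanged the inhibition of growth.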